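Swapping an ether for a sulfonyl: clearance of compound 4

A few compounds are considered here, and "the series" means these few. Any claim that something is new, unique, unknown or untested is made for them only; others in the source may bear on it.

- compound 1 `NCCCCCOc1ccc([C@H]2CC[C@]3(CC2)OOC2(O3)C3CC4CC(C3)CC2C4)cc1` gives < 7 mL.min-1.g-1 as a limit of the assay
- compound 2 `N[C@H]1CC[C@H](Oc2ccc([C@H]3CC[C@]4(CC3)OOC3(O4)C4CC5CC(C4)CC3C5)cc2)CC1` gives < 7 mL.min-1.g-1 as a limit of the assay
- compound 3 `c1cc([C@H]2CC[C@]3(CC2)OOC2(O3)C3CC4CC(C3)CC2C4)ccc1OC1CCNCC1` gives 15 mL.min-1.g-1 as an exact number

Among the compounds with values here, in an ADME assay on microsomes from liver (Homo sapiens) for metabolic stability, read by LC-MS, tested at 1 uM (a higher number here means faster removal of the compound, a lower number slower removal), compound 3 gives 15 mL.min-1.g-1 as the only exact number of the three. Beside it stands the limit of < 7 mL.min-1.g-1 in this assay, at which 2 of the 3 values shown sit, and no exact number. Compound 3 lies higher than both others, with an at least 2.1-fold higher number from compound 1 to compound 3 (0.33 log units; beyond the scatter) and with an at least 2.1-fold higher number from compound 2 to compound 3 (0.33 log units; beyond the scatter) in the same direction. The remaining pair offers a step that the two limits leave unreadable from compound 1 to compound 2 and nothing more.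

Compound 4 `NC1CCN(S(=O)(=O)c2ccc([C@H]3CC[C@]4(CC3)OOC3(O4)C4CC5CC(C4)CC3C5)cc2)CC1` has not yet been measured. Its change from compound 3 is (4-aminopiperidin-1-yl)sulfonyl in place of (piperidin-4-yl)oxy on an aromatic carbon and the new group sits on an aromatic carbon, para to a large group. The measured steps only swap what sits on the oxygen, so none of them covers a sulfonyl link. Compound 4 carries an amino group on its ring, as compound 2 does, and compound 2 gives < 7 mL.min-1.g-1 as a limit. That comparison rests on very few compounds. The expected change is a 1.9-fold lower number from compound 3 to compound 4 (0.27 log units; within the scatter) and this estimate points downward, with a size no larger than the scatter. In this assay the estimated value for compound 4 is 8 mL.min-1.g-1 with an expected range from 4 mL.min-1.g-1 to 18 mL.min-1.g-1 (a reported limit remains possible).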

Compound 4, intrinsic clearance in microsomes: < 7 mL.min-1.g-1
Compound 4: a limit, no number; the forecaster's own chance of this, stated with the estimate: 40%; middle value at least 1.1-fold (0.05 log units) from the limit.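

In this assay, placing (4-aminopiperidin-1-yl)sulfonyl on the aromatic carbon, para to a large group, in place of (piperidin-4-yl)oxy gives an at least 2.1-fold lower number from compound 3 to compound 4 (0.33 log units; beyond the scatter). Within the data shown here, the earlier steps changed only what sits on the oxygen, so this is the first result showing that the linking atom itself can be exchanged at this position, with the sulfonyl link giving a lower number than the ether of compound 3. The steps that join compound 4 to compound 1 and to compound 2 run from one limit to another and cannot be read, and compound 3 remains the only compound with an exact number: the limit of < 7 mL.min-1.g-1 in this assay, at which 3 of the 4 values shown sit.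

The step to compound 4 changes the link and also the way the ring is attached, with the amino group now on the ring rather than the nitrogen within it, so the compounds shown cannot separate these two changes, nor show how far compound 4 lies under its limit. A (piperidin-4-yl)sulfonyl group would keep the attachment of compound 3 while carrying the new link, and a carbonyl link, as in an amide, would show whether the lower number extends beyond the sulfonyl.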